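Swapping the sulfonamide substituent on a TRPV1 antagonist scaffold

The source may hold more compounds than are shown below. What is called first, only, known or untested is meant among the compounds shown, and "the series" means these compounds.

Of the compounds shown here, two sharing the same core have been measured in an assay on cells for antagonist activity at transient receptor potential cation channel subfamily V member 1 (Homo sapiens), read by FLIPR and calcium flux, with a stated time of 15 min; on this read-out higher numbers stand for weaker inhibition and lower numbers for stronger inhibition. Compound 1 `COc1cc(C(C)C(=O)NCc2ccc(C(F)(F)F)nc2N2CCC(C)CC2)cc(F)c1NS(C)(=O)=O` gives 0.3 nM in this assay. Compound 2 `CC1CCN(c2nc(C(F)(F)F)ccc2CNC(=O)C(C)c2ccc(NS(N)(=O)=O)c(F)c2)CC1` gives 2.7 nM in this assay, the higher of the two numbers; the gap between compound 2 and compound 1 lies beyond the usual scatter of repeated measurements, so compound 2 is the weaker inhibitor of the pair.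

Compound 3 `CC1CCN(c2nc(C(F)(F)F)ccc2CNC(=O)C(C)c2ccc(N(CC#N)S(C)(=O)=O)c(F)c2)CC1` has not yet been measured. It differs from compound 2 in one place: (cyanomethyl)(methylsulfonyl)amino in place of sulfamoylamino on an aromatic carbon. The group that leaves carries two hydrogen-bond donors; the group that enters carries none and adds a nitrile on its short chain.

Within the data shown here, no measured pair shows this exact exchange, so the expectation rests on the two numbers available and on the size of the structural change. Compound 3 is expected to give a higher number than compound 2, meaning a step of a 3.7-fold higher number from compound 2 to compound 3 (0.57 log units; beyond the scatter) toward weaker inhibition that is likely beyond the scatter. The estimate for compound 3 in this assay is 10 nM, with a plausible range from 2 nM to 60 nM.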

Compound 3, inhibition constant: "not active" (no number reported)
Compound 3 has no reported number here; no gap can be computed for the estimate.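

In this assay, among these compounds, compound 3 is reported as not active, with no number, so no step from compound 2 to compound 3 can be read. Nothing measured here explains this result. The compounds shown leave open whether losing the sulfamoylamino group or gaining the (cyanomethyl)(methylsulfonyl)amino group accounts for the result.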